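Adding iodine to a compound at the assay limit

The source may report more compounds than this note shows. Statements on the series, on what has been measured and on what is new or still open speak of the compounds shown alone.

In an ADME assay on J774 cells (Mus musculus) for cytotoxicity (a lower number here means that less compound is needed, a higher number that more compound is needed for the effect), compound 1 (`O=c1cc[nH]c2cc(OCCOc3ccccc3)ccc12`) gives > 20000 nM as a limit of the assay and not a number. Compound 2 (`CCCCc1cc2c(=O)cc[nH]c2cc1OCCOc1ccccc1`) gives > 20000 nM as a limit too, so it has no exact value. All the evidence so far is this one limit (the limit of > 20000 nM in this assay, at which 2 of the 2 values shown sit). Compound 3 (`CCCCc1cc2c(=O)c(I)c[nH]c2cc1OCCOc1ccccc1`) differs from compound 2 by one change (iodo in place of hydrogen on an aromatic carbon), which is iodo in place of hydrogen on an aromatic carbon, two atoms from the ring nitrogen. Within the data shown here, the one measured step, butyl in place of hydrogen, is a step that the two limits leave unreadable from compound 1 to compound 2 and offers no size or direction to carry over, so no step beyond the scatter is expected in this assay here. The expected step is a number no higher from compound 2 to compound 3 (the limit leaves the size open) and no larger. For compound 3 the expected value is 20000 nM with an estimated range from 8000 nM to 40000 nM and a good chance of another limit.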

Compound 3, half-maximal effective concentration: > 10000 nM
Compound 3: only a limit was reported; the forecaster's own chance of this, stated with the estimate: 70%; the middle value does not contradict the limit.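

Compound 2 and compound 3 are both reported only as limits of this assay, so no step can be read for iodo in place of hydrogen on an aromatic carbon. The compounds shown leave open what exact concentration of any of them produces the cytotoxic effect.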